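A few compounds are considered here, and "the series" means these few. Any claim that something is new, unique, unknown or untested is made for them only; others in the source may bear on it.

Two compounds share a bicyclic amide core and differ only in a fluorinated cyclopropyl group attached to the carbonyl. Compound 1, `O=C([C@H]1C[C@H]1F)N1CC2CC(C1)N2`, gives 210 nM in an assay on SH-EP1 cells for agonist activity at Neuronal acetylcholine receptor; alpha4/beta2 (Homo sapiens), read by FLIPR and calcium flux; a higher number here means that more compound is needed for the effect, a lower number that less compound is needed. Compound 2, `O=C([C@@H]1C[C@@H]1F)N1CC2CC(C1)N2`, gives 120 nM in the same assay. The step of a 1.8-fold lower number from compound 1 to compound 2 (0.24 log units; within the scatter) is small; the two differ in how their stereocentres are drawn (the fact that one of compounds 1 and 2 is drawn with a defined configuration and the other without, at the place where they differ). On the numbers shown, compound 2 holds the lower of the two values, with compound 1 sitting within the scatter of it, so neither can be called the more active.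

Compound 3, `C[C@@H]1C[C@H]1C(=O)N1CC2CC(C1)N2`, carries the change (2-methylcyclopropyl in place of 2-fluorocyclopropyl on a carbonyl carbon). Among the measured compounds shown here, only one measured step exists, from compound 1 to compound 2, and it concerns the arrangement of the stereocentres rather than the exchange of a fluorine for a methyl, so it offers no direct guide to this change. A modest step is therefore expected, with little basis for a direction. Compound 3 is estimated at 200 nM, between 60 nM and 700 nM, a step of a 1.7-fold higher number from compound 2 to compound 3 (0.22 log units; within the scatter) from compound 2.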

Compound 3, half-maximal effective concentration: 190 nM
The estimate for compound 3 lay 1.1-fold (0.02 log units) above the measured number, and the stated range covers the measured number.
By their numbers in this assay, from the lowest: compounds 2, 3 and 1 (each within the scatter of the next).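

Among the compounds shown here, the earlier pair spoke only to how the stereocentres are drawn, while compound 3 gives the first look at a change of group at this place, on a carbonyl carbon whose other neighbour is an amide-type nitrogen in a ring. In this assay, putting 2-methylcyclopropyl in place of 2-fluorocyclopropyl gives a 1.6-fold higher number from compound 2 to compound 3 (0.20 log units; within the scatter) and a 1.1-fold lower number from compound 1 to compound 3 (0.04 log units; within the scatter), so the fluorine of compounds 1 and 2 is not needed to stay within the scatter of their numbers, and both fluorinated compounds remain level with the methyl compound. The numbers show that the exchange makes no readable difference here, but nothing shown explains why.

The compounds shown leave open how far this tolerance reaches, since both groups compared have the same count of heavy atoms and neither offers anything beyond a small substituent on the three-membered ring, so a longer chain such as ethyl, an amine or a carboxylic acid at that ring carbon could behave differently. Also open, on these data alone, is whether the other drawn forms of 2-methylcyclopropyl would fall within the same scatter.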